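The compounds below may be only part of what the source reports. "The series", "measured", "known", "first", "only" and "open" are said of these compounds alone.

Compound 2 `N#Cc1c(-c2ccc(F)cc2)c(C#N)c(=O)n(/N=C/c2cn(-c3ccccc3)nc2-c2ccccc2)c1N` is one of two measured analogues built on the shared core of compound 1 `N#Cc1c(-c2cccc(F)c2)c(C#N)c(=O)n(/N=C/c2cn(-c3ccccc3)nc2-c2ccccc2)c1N`. In an ADME assay on NIH3T3 cells (Mus musculus) for cytotoxicity, read by MTT assay (on this read-out lower numbers stand for stronger inhibition and higher numbers for weaker inhibition), compound 1 gives 154 ug/mL. In this assay compound 2 reaches only a limit, > 200 ug/mL, which is the limit of > 200 ug/mL in this assay, at which 1 of the 2 values shown sits. Among the measured compounds shown here, the single measured step, an at least 1.2-fold higher number from compound 1 to compound 2 (0.11 log units; that floor lies within the scatter), is the only comparison available and shows nothing beyond the scatter. Compound 3 `N#Cc1c(-c2ccccc2[N+](=O)[O-])c(C#N)c(=O)n(/N=C/c2cn(-c3ccccc3)nc2-c2ccccc2)c1N` differs from compound 2 by 2-nitrophenyl in place of 4-fluorophenyl on an aromatic carbon. For the measured compounds named here, no measured step concerns a nitrophenyl group, and the one measured step is a shift of fluorine that changed little, so there is no ground for expecting a move beyond the scatter. On that basis the expected step is an at least 1.1-fold lower number from compound 2 to compound 3 (0.04 log units; that floor lies within the scatter), within the scatter, and this assay may again report only a limit. The estimate for compound 3 is 180 ug/mL, with a lower end of 80 ug/mL and an upper end of 320 ug/mL.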

Compound 3, half-maximal inhibitory concentration: > 200 ug/mL
Compound 3: only a limit was reported; the forecaster's own chance of this, stated with the estimate: 50%; middle value at least 1.1-fold (0.04 log units) from the limit.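

With a 2-nitrophenyl group at this position, where only fluorophenyl groups had been seen, compound 3 in this assay also gives only a limit, > 200 ug/mL. The change from 3-fluorophenyl to 2-nitrophenyl gives an at least 1.2-fold higher number from compound 1 to compound 3 (0.11 log units; that floor lies within the scatter), so it shows no move beyond the scatter, and the step from compound 2 to compound 3 cannot be read. A second, quite different group at this position has thus ended at the same limit of the read-out: the limit of > 200 ug/mL in this assay, at which 2 of the 3 values shown sit.

The compounds shown leave open how compound 2 and compound 3 compare, as neither has a readable number. They also leave open whether an amine or a carboxylic acid on the phenyl ring at this position would give a number clearly lower than that of compound 1.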